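A Trifluoromethylphenyl Replaces a Methoxyphenyl on the Shared Core

The source may hold more compounds than are shown below. What is called first, only, known or untested is meant among the compounds shown, and "the series" means these compounds.

Of the compounds shown here, three built on one shared core have been measured in an assay on isolated protein for antagonist activity at Bile acid receptor (Homo sapiens), read by TR-FRET, with a stated time of 20 min; on this read-out lower numbers stand for stronger inhibition and higher numbers for weaker inhibition. Compound 1 `Cc1ccc(-c2nn(C(C)C)cc2C(=O)Nc2ccc(C)c(S(=O)(=O)N3CCOCC3)c2)cc1` gives 49.1 nM, compound 2 `COc1cccc(-c2nn(C(C)C)cc2C(=O)Nc2ccc(C)c(S(=O)(=O)N3CCOCC3)c2)c1` gives 160 nM, and compound 3 `COc1cccc(Cn2cc(C(=O)Nc3ccc(C)c(S(=O)(=O)N4CCOCC4)c3)c(-c3cccc(OC)c3)n2)c1` gives 42.8 nM. Compound 2 stands highest of the three numbers: the change gave a 3.3-fold higher number from compound 1 to compound 2 (0.51 log units; beyond the scatter), and the change gave a 3.7-fold lower number from compound 2 to compound 3 (0.57 log units; beyond the scatter). Compound 4 `Cc1ccc(NC(=O)c2cn(C(C)C)nc2-c2ccc(C(F)(F)F)cc2)cc1S(=O)(=O)N1CCOCC1` has not been measured yet; it differs from compound 2 by 4-(trifluoromethyl)phenyl in place of 3-methoxyphenyl on an aromatic carbon. Within the data shown here, the one measured step touching this place is a 3.3-fold higher number from compound 1 to compound 2 (0.51 log units; beyond the scatter), in which the 4-methylphenyl of compound 1 gave the lower number. Compound 4 is therefore expected to come out modestly lower than compound 2, as a 2.3-fold lower number from compound 2 to compound 4 (0.36 log units; beyond the scatter), with an estimated value near 70 nM and a range from 25 nM to 200 nM.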

Compound 4, half-maximal inhibitory concentration: 77.5 nM
Compound 4: middle estimate off by 1.1-fold (0.04 log units), on the low side; low and high end bracket the measured number.
By their numbers in this assay, from the lowest: compounds 3, 1 and 4 (each within the scatter of the next); then compound 2.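

Like the 4-methylphenyl of compound 1, the 4-(trifluoromethyl)phenyl lowers the number relative to the 3-methoxyphenyl of compound 2, here with a 2.1-fold lower number from compound 2 to compound 4 (0.31 log units; beyond the scatter), so a second group at this position now does so. Trifluoromethyl in place of methyl gives a 1.6-fold higher number from compound 1 to compound 4 (0.20 log units; within the scatter), which leaves these two groups unseparated. Nothing available here explains either result. Still open, as far as these compounds go, is how a plain unsubstituted phenyl, or a phenyl carrying an amine or a carboxylic acid, would fare at this position. Also open, from the compounds shown here alone, is whether the 3-methoxybenzyl of compound 3 would lower the number of compound 4 as well.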